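Removing the decyl chain from the triazole-bearing furanone

The source may report more compounds than this note shows. Statements on the series, on what has been measured and on what is new or still open speak of the compounds shown alone.

Working notes on the series. The shared core is that of compound 2 `CCCCCCCCCCc1cn(C[C@H](O)[C@H]2OC(=O)C(OCc3ccccc3)=C2OCc2ccccc2)nn1`. Within the data shown here, in a functional assay on SW-620 cells (Homo sapiens) for antiproliferative activity, read by MTT assay, with a stated time of 72 h (a lower number here means a stronger inhibitor, a higher number a weaker inhibitor), compound 2 gives 45200 nM, the only plain number in the set. Compound 1 `CCCCCc1ccc(-c2cn(C/C=C3\OC(=O)C(OCc4ccccc4)=C3OCc3ccccc3)nn2)cc1` returns only a limit, > 100000 nM. The record therefore rests on (the limit of > 100000 nM in this assay, at which 1 of the 2 values shown sits). Compound 3 `O=C1O[C@H]([C@@H](O)Cn2ccnn2)C(OCc2ccccc2)=C1OCc1ccccc1` is not yet measured; it differs from compound 2 by hydrogen in place of decyl on an aromatic carbon. Among the measured compounds shown here, no step between measured compounds is available for comparison. The expected step of a 2.2-fold higher number from compound 2 to compound 3 (0.34 log units; beyond the scatter) is taken as a move toward weaker inhibition. Compound 3 is thus estimated at 100000 nM, within 40000 nM to 300000 nM, with a substantial chance that only a limit is reported.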

Compound 3, half-maximal inhibitory concentration: > 100000 nM
Compound 3: no number, only a limit; the forecaster's own chance of this, stated with the estimate: 55%; the middle value lies on the limit itself.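

Among these compounds, replacing decyl with hydrogen on the aromatic carbon gives the first readable step: in this assay there is an at least 2.2-fold higher number from compound 2 to compound 3 (0.34 log units; beyond the scatter). As far as these compounds go, for compound 3 the reading of > 100000 nM is a limit, not a number, so the loss of decyl points toward weaker inhibition but its full size stays unknown. The record now sits mostly at that limit: the limit of > 100000 nM in this assay, at which 2 of the 3 values shown sit.

From the compounds shown here alone, how much of the decyl chain is needed remains open, and a shorter chain such as butyl on this aromatic carbon would address that. Going by these compounds, whether an amine at this place would restore a plain number is also open.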